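Fluoro for methyl on the indole ring of compound 3

The source may hold more compounds than are shown below. What is called first, only, known or untested is meant among the compounds shown, and "the series" means these compounds.

Measured so far:
Compound 1, `COC(=O)[C@@]1(C)CCC=C2[C@@H]1CC[C@@H](C)[C@]2(C)Cc1c[nH]c2ccccc12`: 4200 nM
Compound 2, `COC(=O)[C@@]1(C)CCC=C2[C@@H]1CC[C@@H](C)[C@]2(C)Cc1c[nH]c2ccc(C)cc12`: 20000 nM
Compound 3, `COC(=O)[C@@]1(C)CCC=C2[C@@H]1CC[C@@H](C)[C@]2(C)Cc1c(C)[nH]c2ccc(C)cc12`: 31000 nM

In a functional assay on T47D cells (Homo sapiens) for inhibition, read by sulforhodamine B assay, with a stated time of 48 h (a higher number here means a weaker inhibitor of growth, a lower number a stronger inhibitor of growth), compound 3 gives the highest number of the three, though the gap to compound 2 is within the scatter; only compound 1 stands clearly lower. Compound 4, `COC(=O)[C@@]1(C)CCC=C2[C@@H]1CC[C@@H](C)[C@]2(C)Cc1c(C)[nH]c2ccc(F)cc12`, differs from compound 3 by fluoro in place of methyl on an aromatic carbon. The most telling measured step is a 4.8-fold higher number from compound 1 to compound 2 (0.68 log units; beyond the scatter), where a methyl entering an aromatic carbon raised the number; removing that methyl in favour of fluoro should partly undo this. The step of a 1.6-fold higher number from compound 2 to compound 3 (0.19 log units; within the scatter) does not bear directly. Compound 4 is therefore expected to fall by a 2.6-fold lower number from compound 3 to compound 4 (0.41 log units; beyond the scatter), landing near 12000 nM within 5000 nM to 35000 nM.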

Compound 4, concentration for 50% growth inhibition: 15000 nM
Compound 4: the middle estimate sits 1.3-fold (0.10 log units) below what was measured, within the range that was stated.
By their numbers in this assay, from the lowest: compound 1; then compounds 4, 2 and 3 (each within the scatter of the next, the first and the last beyond it).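

In this assay this aromatic carbon had so far shown only methyl replacing hydrogen, with a 4.8-fold higher number from compound 1 to compound 2 (0.68 log units; beyond the scatter) as the result. Fluoro replacing methyl at the same carbon now gives a 2.1-fold lower number from compound 3 to compound 4 (0.32 log units; beyond the scatter) so the number also moves when one substituent is exchanged for another, not only when a methyl is added. Nothing available here explains this change.

On these data alone, whether fluoro gives a lower number than hydrogen at this carbon remains open, since compound 3 and compound 4 have no partner with hydrogen there. As far as these compounds go, how chloro, methoxy or a nitrile would behave at this carbon is also open.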